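A few compounds are considered here, and "the series" means these few. Any claim that something is new, unique, unknown or untested is made for them only; others in the source may bear on it.

Measured so far in a functional assay on MCF7 cells (Homo sapiens) for cytotoxicity, read by MTT assay, with a stated time of 48 h; on this read-out higher numbers stand for weaker inhibition and lower numbers for stronger inhibition:

- compound 1 `Cc1ccc(S(=O)(=O)/N=C(/CCNC2=CC(=O)c3ccccc3C2=O)Nc2ccc(Cl)cc2)cc1`: 7080 nM
- compound 2 `Cc1ccc(S(=O)(=O)/N=C(/CCNC2=CC(=O)c3ccccc3C2=O)Nc2cc(F)c(F)c(F)c2)cc1`: 6610 nM

Compound 2 holds the lowest of the two numbers, with compound 1 nearest; the gap between them is within the scatter, so the two stand level on this read-out.

Compound 3 `Cc1ccc(S(=O)(=O)/N=C(/CCNC2=CC(=O)c3ccccc3C2=O)NC2CCCCC2)cc1` is the next member. Relative to compound 2 it carries cyclohexyl in place of 3,4,5-trifluorophenyl on an amine nitrogen, that is, (3,4,5-trifluorophenyl)amino becomes cyclohexylamino, the group sitting on an amine nitrogen whose other neighbour is a carbon with a double bond to nitrogen.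

Among the compounds with values here, the one measured step at this position, a 1.1-fold lower number from compound 1 to compound 2 (0.03 log units; within the scatter), exchanged one substituted phenyl for another and stayed within the scatter. Within the data shown here, no measured step exchanges the six-membered aromatic ring for a non-aromatic one, so that step bears only loosely on the present change. Among the measured compounds shown here, with the only evidence on this site being flat, no move beyond the scatter is expected in this assay, and the step is estimated as a 1.1-fold higher number from compound 2 to compound 3 (0.02 log units; within the scatter), with a wide range to cover the untested ring change.

Compound 3 is therefore expected to give about 7000 nM, between 2500 nM and 20000 nM.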

Compound 3, half-maximal inhibitory concentration: 7580 nM
Estimate against measurement, compound 3: 1.1-fold (0.03 log units) below; the measured number falls inside the stated range.
By their numbers in this assay, from the lowest: compounds 2, 1 and 3 (each within the scatter of the next).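

In this assay the change from an aromatic to a non-aromatic six-membered carbon ring on this amine nitrogen, with cyclohexyl in place of 3,4,5-trifluorophenyl, gives a 1.1-fold higher number from compound 2 to compound 3 (0.06 log units; within the scatter), and cyclohexyl in place of 4-chlorophenyl gives a 1.1-fold higher number from compound 1 to compound 3 (0.03 log units; within the scatter). Within the data shown here, the earlier comparison covered only one substituted phenyl against another; these two steps extend the flat picture to a ring with no aromaticity and no halogen, so among compounds 1, 2 and 3 neither feature separates the numbers on this read-out, and no compound goes against that reading. No measurement on hand offers an explanation for this flat result.

Still open, as far as these compounds go, is whether this position stays flat with groups of a different kind on the same nitrogen, such as a morpholine ring, a phenyl bearing a carboxylic acid, a small methyl or a longer alkyl chain. The three compounds also share the rest of the core, so they leave open how far the number moves with a change made elsewhere on it.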